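Swapping Fluoro for Chloro on a Second Scaffold

The source may hold more compounds than are shown below. What is called first, only, known or untested is meant among the compounds shown, and "the series" means these compounds.

Compound 1 `COc1ccc(-c2ccc3c(c2)C(=O)C(=O)N3Cc2ccc(F)cc2)cc1` and compound 2 `COc1ccc(-c2ccc3c(c2)C(=O)C(=O)N3Cc2ccc(Cl)cc2)cc1` share one core and differ in a single place: chloro in place of fluoro on an aromatic carbon. In a functional assay on HepG2 cells (Homo sapiens) for antiproliferative activity, read by MTT assay, with a stated time of 48 h (a higher number here means a weaker inhibitor, a lower number a stronger inhibitor), compound 1 gives 1120 nM, and compound 2 gives 250 nM, so the step is a 4.5-fold lower number from compound 1 to compound 2 (0.65 log units; beyond the scatter). Compound 3 `COc1ccc(CN2C(=O)C(=O)c3cc(-c4ccc(F)cc4)ccc32)cc1` is made of the same atoms as compound 1 joined differently; the difference between the two cores is not broken down here. In this assay compound 3 gives 3150 nM, the highest of the three numbers. Compound 4 `COc1ccc(CN2C(=O)C(=O)c3cc(-c4ccc(Cl)cc4)ccc32)cc1` has not been measured and differs from compound 3 by the same change: chloro in place of fluoro on an aromatic carbon. The place is described in the same words for both pairs, though for compound 1 to compound 2 the difference cut one bond further out also reads 4-fluorobenzyl to 4-chlorobenzyl, which does not hold here. Going by the values given here, because a 4.5-fold lower number from compound 1 to compound 2 (0.65 log units; beyond the scatter) was modest, a step of similar kind is expected, a 2.4-fold lower number from compound 3 to compound 4 (0.38 log units; beyond the scatter); only one such pair is known, so some caution applies. Compound 4 is estimated at 1300 nM, expected between 500 nM and 3500 nM.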

Compound 4, half-maximal inhibitory concentration: 380 nM
Compound 4: the middle estimate sits 3.4-fold (0.53 log units) above what was measured, and the stated range ends above it.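

In this assay, chloro in place of fluoro again goes with a lower number, this time an 8.3-fold lower number from compound 3 to compound 4 (0.92 log units; beyond the scatter). The change therefore points the same way on both cores, and the two steps cannot be told apart in size: the same change on two cores in this assay, a 4.5-fold lower number (0.65 log units; beyond the scatter) from compound 1 to compound 2 and an 8.3-fold lower number (0.92 log units; beyond the scatter) from compound 3 to compound 4, 1.9-fold (0.27 log units) apart, within the scatter of two such steps. This shows that, in these two pairs, the gain seen on one core also appears on the other, even though the change reads 4-fluorobenzyl to 4-chlorobenzyl in the first pair and 4-fluorophenyl to 4-chlorophenyl in the second, but two pairs in a single cell assay do not show why the number falls or that the same would happen on a third core.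

The compounds shown leave open whether the lower number belongs to chloro alone or would also come with bromo, methyl or trifluoromethyl on the same aromatic carbon. They also leave open how an amine or a carboxylic acid would fare there, since only two halogens have been compared in this place.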